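Morpholine amide in place of the anilide of compound 1

The compounds below may be only part of what the source reports. "The series", "measured", "known", "first", "only" and "open" are said of these compounds alone.

compound 1 `O=C(CCC(=O)OCCCCCCSc1ccc([N+](=O)[O-])c2nonc12)Nc1ccccc1Cl` 335000 nM
compound 2 `O=C(CCC(=O)OCCCCCCSc1ccc([N+](=O)[O-])c2nonc12)Nc1ccc(Br)cc1` 2160 nM
compound 3 `Cc1ccc(NC(=O)CCC(=O)OCCCCCCSc2ccc([N+](=O)[O-])c3nonc23)cc1` 3340 nM

In a functional assay on HOS cells (Homo sapiens) for inhibition, read by MTT assay, with a stated time of 72 h (a higher number here means a weaker inhibitor, a lower number a stronger inhibitor), compound 1 gives 335000 nM, the highest of the three numbers. From compound 1 the steps are a 160-fold lower number from compound 1 to compound 2 (2.19 log units; beyond the scatter) and a 100-fold lower number from compound 1 to compound 3 (2.00 log units; beyond the scatter); between the other two, a 1.5-fold higher number from compound 2 to compound 3 (0.19 log units; within the scatter). Compound 4 `O=C(CCC(=O)N1CCOCC1)OCCCCCCSc1ccc([N+](=O)[O-])c2nonc12` differs from compound 1 by morpholin-4-yl in place of (2-chlorophenyl)amino on a carbonyl carbon. Both measured steps from compound 1 remove the (2-chlorophenyl)amino group and both are large, yet each brings in another substituted phenyl rather than morpholin-4-yl, so neither covers this change directly. A lower number is nevertheless expected for compound 4 because compound 1 stands so far above the others in a 160-fold lower number from compound 1 to compound 2 (2.19 log units; beyond the scatter), with wide uncertainty. Compound 4 is estimated at 25000 nM, between 3000 nM and 200000 nM, which would mean a 13-fold lower number from compound 1 to compound 4 (1.13 log units; beyond the scatter).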

Compound 4, half-maximal inhibitory concentration: 1010 nM
For compound 4 the middle estimate is 25-fold (1.39 log units) above the measured one; measured number outside the range, below it.
By their numbers in this assay, from the lowest: compound 4; then compounds 2 and 3 (each within the scatter of the next); then compound 1.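

With morpholin-4-yl on the carbonyl carbon, the series no longer needs an aryl amino group or the amide hydrogen to act in this assay. The change gives a 330-fold lower number from compound 1 to compound 4 (2.52 log units; beyond the scatter) and also improves on the para-free comparison of the two better anilides, with a 3.3-fold lower number from compound 3 to compound 4 (0.52 log units; beyond the scatter) and a 2.1-fold lower number from compound 2 to compound 4 (0.33 log units; beyond the scatter) as its steps. All three steps are beyond the scatter, so compound 4 is the strongest of the four. No measurement shown here explains this result.

From the compounds shown here alone, whether the ring oxygen matters remains open, and a piperidin-1-yl amide would test this. An open-chain dimethylamino amide would show whether the ring itself is needed.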